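From chloro to fluoro: one change on compound 2

The source may report more compounds than this note shows. Statements on the series, on what has been measured and on what is new or still open speak of the compounds shown alone.

Measured so far:
compound 1 `c1ccc([C@H]2OC[C@H]([C@@H]3CCCCN3)O2)cc1` gives 25000 nM
compound 2 `CC[C@]1(c2ccccc2Cl)OC[C@H]([C@@H]2CCCCN2)O1` gives 14.3 nM
compound 3 `CC[C@]1(c2cccc(N)c2)OC[C@H]([C@@H]2CCCCN2)O1` gives 1230 nM

All three were tested in a functional assay (brain) for displacement of a labelled ligand, with Rattus norvegicus as the target; a lower number here means a stronger inhibitor, a higher number a weaker inhibitor. Compound 2 has the lowest number of the three, so it is the strongest inhibitor here. The nearest of the others is compound 3, whose number is higher by a gap that lies beyond the scatter; compound 1 is furthest away, again beyond the scatter. Compound 2 therefore stands clearly apart from both.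

Compound 4 `CC[C@]1(c2ccccc2F)OC[C@H]([C@@H]2CCCCN2)O1` is not yet measured. It differs from compound 2 in one place: fluoro in place of chloro on an aromatic carbon. The group that leaves and the group that enters are each a single halogen, so the shape of the molecule is otherwise unchanged.

Going by the values given here, no pair of measured compounds shows a halogen swap of this kind, so there is no directly comparable step to lean on. The expectation is a small loss of potency for compound 4, probably close to the scatter of this assay. Compound 4 is estimated at 45 nM, with a range from 12 nM to 170 nM. The expected step of a 3.1-fold higher number from compound 2 to compound 4 (0.50 log units; beyond the scatter) is a modest weakening relative to compound 2.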

Compound 4, inhibition constant: 36 nM
Compound 4: middle estimate off by 1.3-fold (0.10 log units), on the high side; the measured number falls inside the stated range.
By their numbers in this assay, from the lowest: compound 2; then compound 4; then compound 3; then compound 1.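

In this assay, going by these compounds alone, the swap of chloro for fluoro gives a 2.5-fold higher number from compound 2 to compound 4 (0.40 log units; beyond the scatter), the first step in this set that can be read at a single place. The position, on an aromatic carbon and ortho to a large group, therefore distinguishes between these two halogens, since the step lies beyond the scatter, but the exchange of one for the other costs only a modest amount of potency, and compound 4 at 36 nM remains a strong inhibitor. No measurement shown here accounts for the lower number with chloro.

Going by these compounds, a single step between two halogens gives a direction for this pair only and cannot establish a trend, so it remains open whether bromo, methyl or methoxy at this position would give a lower or a higher number than chloro or fluoro, or whether an unsubstituted carbon there would lose much more. On these data alone, it is also open whether the same exchange would give a step of similar size elsewhere on the aromatic ring, or with a longer chain in place of the ethyl group.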